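Swapping the Sulfonamide Ring Partner in a Thiourea Series

This account rests on a few compounds, and the source may have more. Where it says the series, first, only, none or still open, it means among the compounds named here.

Three compounds share one core in which a thiourea links a trifluoromethyl-bearing bicyclic amine to a benzenesulfonamide, and they differ only in what sits on the sulfonamide nitrogen. Compound 1 `N=C(N)NS(=O)(=O)c1ccc(N/C(S)=N\c2ccnc3cc(C(F)(F)F)ccc23)cc1` carries an open-chain guanidine group there; in a functional assay on AS49-RAW cells (Homo sapiens) for antiproliferative activity, read by sulforhodamine B assay, with a stated time of 48 h (a higher number here means a weaker inhibitor, a lower number a stronger inhibitor), compound 1 gives 23900 nM. Compound 2 `Cc1cc(NS(=O)(=O)c2ccc(N/C(S)=N\c3ccnc4cc(C(F)(F)F)ccc34)cc2)on1` carries a methyl-substituted oxazole ring, and in this assay compound 2 gives 60200 nM. Compound 3 `O=S(=O)(Nc1nccs1)c1ccc(N/C(S)=N\c2ccnc3cc(C(F)(F)F)ccc23)cc1` carries a thiazole ring, and in this assay compound 3 gives 27200 nM. Among these three numbers compound 3 stands second highest: the step of a 1.1-fold higher number from compound 1 to compound 3 (0.06 log units; within the scatter) lies within the scatter, while the step of a 2.2-fold lower number from compound 2 to compound 3 (0.35 log units; beyond the scatter) is modest but real, as is a 2.5-fold higher number from compound 1 to compound 2 (0.40 log units; beyond the scatter).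

Compound 4 `Cc1ccnc(NS(=O)(=O)c2ccc(N/C(S)=N\c3ccnc4cc(C(F)(F)F)ccc34)cc2)n1` is the next member. Its change from compound 3 is 4-methylpyrimidin-2-yl in place of 1,3-thiazol-2-yl on a sulfonamide nitrogen. Two of the measured steps exchange one ring partner for another on this nitrogen, and neither moves the number far. Exchanging the thiazole for a methylpyrimidine is a comparable edit, so the expected step of a 1.2-fold higher number from compound 3 to compound 4 (0.07 log units; within the scatter) is small and may not exceed the scatter. In this assay compound 4 is therefore estimated at 32000 nM, with a likely range from 13000 nM to 80000 nM.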

Compound 4, half-maximal inhibitory concentration: 31000 nM
Compound 4: middle estimate off by 1.0-fold (0.01 log units), on the high side, within the range that was stated.
By their numbers in this assay, from the lowest: compounds 1, 3, 4 and 2 (each within the scatter of the next, the first and the last beyond it).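

In this assay, going by these compounds alone, the step of a 1.1-fold higher number from compound 3 to compound 4 (0.06 log units; within the scatter) shows that a six-membered aromatic ring can take the place of a five-membered one on the sulfonamide nitrogen without a change beyond the scatter, a ring size that the earlier compounds did not cover. The steps of a 1.3-fold higher number from compound 1 to compound 4 (0.11 log units; within the scatter) and a 1.9-fold lower number from compound 2 to compound 4 (0.29 log units; within the scatter) also lie within the scatter, so this new member cannot be told apart from any of the other three, even though the gap between the open-chain guanidine of compound 1 and the oxazole of compound 2 is real. No measurement is available that explains why these ring exchanges change the number so little.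

The compounds shown leave open how much of the result belongs to the pyrimidine ring and how much to its methyl group, a question that the same ring without the methyl would address. They also leave open whether a quite different group on this nitrogen, such as a plain phenyl ring, a carboxylic acid or a longer alkyl chain, would move the number further than any ring partner here.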